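The source may report more compounds than this note shows. Statements on the series, on what has been measured and on what is new or still open speak of the compounds shown alone.

Measured compounds in an ADME assay on the whole organism with Oryza sativa as the target, tested at 1 uM; on this read-out lower numbers stand for a stronger effect and higher numbers for a weaker effect at the one concentration tested:
compound 1, `C[C@H](NC(=O)Nc1ccccc1F)c1ccccc1`, 92%
compound 2, `C[C@@H](NC(=O)Nc1ccc(F)cc1)c1ccccc1`, 96%
compound 3, `C[C@H](NC(=O)Nc1ccc(F)cc1F)c1ccccc1`, 100%

Compound 1 and compound 2 have the same atoms joined differently; the difference between the two cores is not broken down here. Their values in this assay sit within the scatter of each other, as does the pair of compound 2 and compound 3. From compound 1 to compound 3 the change is fluoro in place of hydrogen on an aromatic carbon, and it gives a number 8 percentage points higher from compound 1 to compound 3 (within the scatter).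

Compound 4, `C[C@@H](NC(=O)Nc1ccc(F)c(F)c1)c1ccccc1`, is not yet measured. It differs from compound 2 by fluoro in place of hydrogen on an aromatic carbon. This is the same kind of change as from compound 1 to compound 3, not the same: there the entering fluoro sits meta to a fluoro group and para to a large group, here ortho to a fluoro group and meta to a large group. The step is expected to be small, a number 2 percentage points higher from compound 2 to compound 4 (within the scatter), because the earlier step gave a number 8 percentage points higher from compound 1 to compound 3 (within the scatter). Compound 4 is thus estimated at 98%, with a range from 90% to 104%.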

Compound 4, a percentage reported as activity, at one concentration (the size of the read-out at that concentration, not a potency): 99%
The estimate for compound 4 lay 1 percentage points below the measured number; the range from low to high includes it.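

In this assay, fluoro in place of hydrogen on an aromatic carbon gives a number 3 percentage points higher from compound 2 to compound 4 (within the scatter). Set beside the earlier step, the change shows no detectable difference between the two cores: the same change on two cores in this assay, a number 8 percentage points higher (within the scatter) from compound 1 to compound 3 and a number 3 percentage points higher (within the scatter) from compound 2 to compound 4, 5 percentage points apart, within the scatter of two such steps. This shows that the step stays within the scatter on both cores, but it does not show that the change is without effect or that it would stay so on other cores or at other places on the ring, as the entering fluoro has a different place in each case.

The compounds shown carry only fluoro groups as ring substituents. Going by these compounds, whether a methoxy group, a trifluoromethyl group, an amine or a carboxylic acid would shift the read-out remains open.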